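This account rests on a few compounds, and the source may have more. Where it says the series, first, only, none or still open, it means among the compounds named here.

Compound 1 `Cc1ccc(OCC(=O)N(CCCO)Cc2cccs2)cc1` and compound 2 `CCN(Cc1cccs1)C(=O)c1cc2cc(C)ccc2[nH]1` share a thienylmethyl group on an amide-type nitrogen and were both tested in an assay on HEK293 cells for agonist activity at transient receptor potential cation channel subfamily M member 8 (Homo sapiens), read by fluorescence and calcium flux, with a stated time of 15 min; a higher number here means that more compound is needed for the effect, a lower number that less compound is needed. In this assay compound 1 gives 3000 nM, and compound 2 gives 2010 nM; the two numbers lie within the scatter of each other, so neither can be set above the other. Compound 3 `Cc1ccc(OCC(=O)N(Cc2cccs2)c2cnccn2)cc1` has not yet been measured in this assay. It differs from compound 1 in one place: pyrazin-2-yl in place of 3-hydroxypropyl on an amide-type nitrogen. Going by the values given here, no pair of measured compounds shows what such a change does here, and nothing among the two measured values points in a particular direction. The step from compound 1 to compound 3 in this assay is therefore expected to stay within the scatter, with a 1.2-fold lower number from compound 1 to compound 3 (0.08 log units; within the scatter) as the expected change. For compound 3 the estimated value in this assay is 2500 nM, with a likely range from 800 nM to 8000 nM.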

Compound 3, half-maximal effective concentration: 1240 nM
For compound 3 the middle estimate is 2.0-fold (0.30 log units) above the measured one; low and high end bracket the measured number.
By their numbers in this assay, from the lowest: compounds 3, 2 and 1 (each within the scatter of the next, the first and the last beyond it).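

In this assay, going by these compounds alone, pyrazin-2-yl in place of 3-hydroxypropyl on the amide-type nitrogen gives a 2.4-fold lower number from compound 1 to compound 3 (0.38 log units; beyond the scatter) and is the first readable step at this position, though a modest one. It shows that this place accepts a six-membered aromatic ring with 2 hetero atoms instead of a chain without a ring, and that the number does not rise when the hydrogen-bond donor of 3-hydroxypropyl leaves. No measurement at hand gives a reason for this step.

Going by these compounds, how a phenyl ring, a pyridin-2-yl ring or a plain propyl chain would read on this nitrogen remains open, so the part played by the ring cannot be separated from that of the departing hydroxyl. Also open, on these data alone, is what an amine or a carboxylic acid at the end of the chain would do.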